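Nitrooxy carbamate variants on the sulfonyl diazepane core

This account rests on a few compounds, and the source may have more. Where it says the series, first, only, none or still open, it means among the compounds named here.

Three carbamates sharing one core have been measured in an assay on isolated protein for inhibition of Rho-associated protein kinase 1 (Homo sapiens), read by HTRF, with a stated time of 1 h; on this read-out lower numbers stand for stronger inhibition and higher numbers for weaker inhibition. Compound 1 `C[C@H]1CN(C(=O)OCCCO[N+](=O)[O-])CCCN1S(=O)(=O)c1cccc2cncc(F)c12` gives 104 nM. Compound 2 `C[C@H]1CN(C(=O)OCCCCCO[N+](=O)[O-])CCCN1S(=O)(=O)c1cccc2cncc(F)c12` gives 44.6 nM, and compound 3 `C[C@H]1CN(C(=O)OCCO[N+](=O)[O-])CCCN1S(=O)(=O)c1cccc2cncc(F)c12` gives 47.3 nM. Compound 3 stands second highest of the three numbers; its nearest neighbour is compound 2, and the gap there is within the scatter, as a 1.1-fold higher number from compound 2 to compound 3 (0.03 log units; within the scatter) shows. The step of a 2.2-fold lower number from compound 1 to compound 3 (0.34 log units; beyond the scatter) is modest but beyond the scatter, as is a 2.3-fold lower number from compound 1 to compound 2 (0.37 log units; beyond the scatter).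

Compound 4 `C[C@H]1CN(C(=O)O[C@@H]2CO[C@H]3[C@@H]2OC[C@@H]3O[N+](=O)[O-])CCCN1S(=O)(=O)c1cccc2cncc(F)c12` differs from compound 3 in that (a group of 12 heavy atoms (6 carbon, 1 nitrogen, 5 oxygen; 2 five-membered non-aromatic rings with 1 hetero atom each) in place of a group of 6 heavy atoms (2 carbon, 1 nitrogen, 3 oxygen; no ring), on an oxygen next to a carbonyl group); the entering group carries four defined stereocentres and two five-membered non-aromatic rings with one hetero atom each. All three measured steps only alter the length of the chain bearing the nitrooxy, and none introduces a ring; they therefore bear on this change only loosely and point to shifts at most modest in size. On that basis the step of a 1.2-fold higher number from compound 3 to compound 4 (0.07 log units; within the scatter) is expected to stay within the scatter, with wide uncertainty. Compound 4 is estimated at 55 nM, within a range from 20 nM to 150 nM.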

Compound 4, half-maximal inhibitory concentration: 53.6 nM
Estimate against measurement, compound 4: 1.0-fold (0.01 log units) above; low and high end bracket the measured number.
By their numbers in this assay, from the lowest: compounds 2, 3, 4 and 1 (each within the scatter of the next, the first and the last beyond it).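

On an oxygen next to a carbonyl group, the group with two five-membered non-aromatic rings and four defined stereocentres replaces 2-(nitrooxy)ethyl with no shift beyond the scatter in this assay (a 1.1-fold higher number from compound 3 to compound 4 (0.05 log units; within the scatter)), and the same holds against the longer chain (a 1.2-fold higher number from compound 2 to compound 4 (0.08 log units; within the scatter)). This position therefore accepts a ring-bearing group as well as open chains, at least for this one example. The gap to the chain of compound 1 also stays within the scatter (a 1.9-fold lower number from compound 1 to compound 4 (0.29 log units; within the scatter)), although the steps from compound 1 to compound 2 and compound 3 lie beyond it, and no measured evidence accompanies these results.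

From the compounds shown here alone, whether this holds for a group lacking nitrooxy, such as a plain ethyl or a carboxylic acid-bearing chain, remains open. The compounds shown also leave open whether the four stereocentres of the entering group matter.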